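A few compounds are considered here, and "the series" means these few. Any claim that something is new, unique, unknown or untested is made for them only; others in the source may bear on it.

Compound 1 `COc1cc(N)c(Cl)cc1NC(=O)C1CCN(Cc2cccc(C)c2)CC1` bears a 3-methylbenzyl group on its shared core. Going by the values given here, in a functional assay on the whole organism for antagonist activity, with Mus musculus as the target (on this read-out lower numbers stand for an effect already at smaller amounts and higher numbers for an effect only at larger amounts of compound), compound 1 gives 2.4 mg/kg, the only real number among the three measured compounds. Compound 2 `COc1cc(N)c(Cl)cc1NC(=O)C1CCN(Cc2cccc(C#N)c2)CC1` reaches only an assay limit, > 4 mg/kg. Compound 3 `COc1cccc(CN2CCC(C(=O)Nc3cc(Cl)c(N)cc3OC)CC2)c1` likewise gives only a limit, > 4 mg/kg. The steps of an at least 1.6-fold higher number from compound 1 to compound 2 (0.22 log units; that floor lies within the scatter) and an at least 1.6-fold higher number from compound 1 to compound 3 (0.22 log units; that floor lies within the scatter) both run into (the limit of > 4 mg/kg in this assay, at which 2 of the 3 values shown sit), while the step that the two limits leave unreadable from compound 2 to compound 3 cannot be sized. Compound 4 `COc1cc(N)c(Cl)cc1NC(=O)C1CCN(Cc2ccc(F)cc2)CC1` differs from compound 1 by 4-fluorophenyl in place of 3-methylphenyl on a saturated chain carbon bound to an amine nitrogen in a ring. Because an at least 1.6-fold higher number from compound 1 to compound 2 (0.22 log units; that floor lies within the scatter) and an at least 1.6-fold higher number from compound 1 to compound 3 (0.22 log units; that floor lies within the scatter) both point toward larger doses, compound 4 is expected to need a larger dose too, with an estimated step of a 1.7-fold higher number from compound 1 to compound 4 (0.22 log units; within the scatter), and it may itself end at the limit. The estimate for compound 4 is 4 mg/kg, within 2 mg/kg to 8 mg/kg.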

Compound 4, dose for half-maximal effect: 0.6 mg/kg
For compound 4 the middle estimate is 6.7-fold (0.82 log units) above the measured one; measured number outside the range, below it.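

In this assay, this place, a saturated chain carbon bound to an amine nitrogen in a ring, can move toward smaller doses: 3-methylphenyl to 4-fluorophenyl gives a 4.0-fold lower number from compound 1 to compound 4 (0.60 log units; beyond the scatter). Replacing 3-cyanophenyl gives an at least 6.6-fold lower number from compound 2 to compound 4 (0.82 log units; beyond the scatter), and replacing 3-methoxyphenyl gives an at least 6.6-fold lower number from compound 3 to compound 4 (0.82 log units; beyond the scatter). These last two steps are only floors, set by a limit of the assay: the limit of > 4 mg/kg in this assay, at which 2 of the 4 values shown sit.

Going by these compounds, whether this step comes from the fluorine itself or from the change in the group's numbered place stays open. Also open, on these data alone, is what a chlorine or an amine in place of the fluorine would give.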